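The compounds below may be only part of what the source reports. "The series", "measured", "known", "first", "only" and "open" are said of these compounds alone.

Compound 1, `COc1cc(/C=C/C(=O)c2cccc(NC(=O)c3ccco3)c2)ccc1O`: 5.46 ug/mL
Compound 2, `COc1cc(/C=C/C(=O)c2cccc(NC(=O)c3cc(Cl)cc(Cl)c3)c2)ccc1O`: 4.83 ug/mL
Compound 3, `CCOC(=O)C(=O)Nc1cccc(C(=O)/C=C/c2ccc(O)c(OC)c2)c1`: 7.03 ug/mL

These three compounds were measured in a functional assay on B16 cells (Mus musculus) for inhibition; a higher number here means a weaker inhibitor, a lower number a stronger inhibitor. They share a core and differ only in the group attached to a carbonyl carbon whose other neighbour is an amide-type nitrogen. Compound 1 holds the second highest of the three numbers. Its nearest neighbour is compound 2, reached by a 1.1-fold lower number from compound 1 to compound 2 (0.05 log units; within the scatter), and its furthest is compound 3, reached by a 1.3-fold higher number from compound 1 to compound 3 (0.11 log units; within the scatter). The remaining pair gives a 1.5-fold higher number from compound 2 to compound 3 (0.16 log units; within the scatter). None of these steps leaves the scatter, so on what has been measured the three compounds cannot be told apart in this assay.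

Compound 4, `COc1cc(/C=C/C(=O)c2cccc(NC(=O)c3cccs3)c2)ccc1O`, has not yet been measured there. It differs from compound 1 in one place: thiophen-2-yl in place of furan-2-yl on a carbonyl carbon. All three measured steps bear on this change, since each swaps the group on the same carbonyl carbon, and each stayed within the scatter. On that basis no step beyond the scatter is expected from compound 1 to compound 4, that is, the expected step is a 1.0-fold higher number from compound 1 to compound 4 (0.00 log units; within the scatter). Compound 4 is therefore estimated at 5.5 ug/mL in this assay, with a range from 3.5 ug/mL to 8.5 ug/mL.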

Compound 4, half-maximal inhibitory concentration: 6.93 ug/mL
Estimate against measurement, compound 4: 1.3-fold (0.10 log units) below; measured number inside the range.
By their numbers in this assay, from the lowest: compounds 2, 1, 4 and 3 (each within the scatter of the next).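

In this assay, exchanging one five-membered aromatic ring for another on this carbonyl carbon, with sulfur entering where oxygen leaves, gives a 1.3-fold higher number from compound 1 to compound 4 (0.10 log units; within the scatter) and so adds a swap of the ring hetero atom alone to the earlier swaps of whole groups. The thiophen-2-yl group is also compared with the two other groups, giving a 1.0-fold lower number from compound 3 to compound 4 (0.01 log units; within the scatter) and a 1.4-fold higher number from compound 2 to compound 4 (0.16 log units; within the scatter), so all four groups on this carbonyl carbon, furan-2-yl, thiophen-2-yl, 3,5-dichlorophenyl and ethoxycarbonyl, now cannot be told apart in this assay even though they include two five-membered aromatic rings, a chlorinated phenyl ring and an ester. Nothing is available that would explain why the numbers stay this close at this position.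

The compounds shown leave open whether the same holds for groups of another kind on this carbonyl carbon, such as a simple amine, a carboxylic acid or a longer alkyl chain. They also leave open whether a six-membered ring with a ring nitrogen, such as pyridin-3-yl, or a thiophen-2-yl ring carrying a chlorine would stay within the scatter of compound 1 in this assay.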